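Trimming the ether tail of compound 1: expected potency

A few compounds are considered here, and "the series" means these few. Any claim that something is new, unique, unknown or untested is made for them only; others in the source may bear on it.

Measured compounds:
compound 1 `O=C(O)Cn1nc(Cc2nc3cc(Cl)c(OCC(F)F)cc3[nH]2)c2ccccc2c1=O` — 15 nM
compound 2 `C[C@@H](C(=O)O)c1nn(Cc2cn3cc(OCC4CC4)c(Cl)cc3n2)c2ccccc2c1=O` — 253 nM
compound 3 `O=C(O)C1(c2nn(Cc3cn4cc(OCC5CC5)c(Cl)cc4n3)c3ccccc3c2=O)CC1` — 82 nM

In a functional assay on CHO cells for antagonist activity at sphingosine 1-phosphate receptor 2 (Homo sapiens), read by GTPgammaS binding (a higher number here means a weaker inhibitor, a lower number a stronger inhibitor), compound 1 gives the lowest number of the three. Compound 3 sits further up in this assay, and compound 2 further still. For the measured compounds named here, the only single-change step among the measured compounds is a 3.1-fold lower number from compound 2 to compound 3 (0.49 log units; beyond the scatter), and it concerns the carboxylic acid side chain, not the ether tail.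

Compound 4 `COc1cc2[nH]c(Cc3nn(CC(=O)O)c(=O)c4ccccc34)nc2cc1Cl` differs from compound 1 by hydrogen in place of difluoromethyl on a saturated chain carbon bound to an oxygen on an aromatic ring. Going by the values given here, no measured pair isolates this change: compounds 2 and 3 carry a different core and a different ether tail from compound 1, so their values say nothing direct about removing the difluoromethyl. The expectation therefore rests on compound 1 alone, with wide uncertainty.

On that basis compound 4 is estimated to show a step of a 2.7-fold higher number from compound 1 to compound 4 (0.43 log units; beyond the scatter), which is expected to stay close to the scatter. Compound 4 is estimated at 40 nM, with a plausible range from 10 nM to 160 nM.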

Compound 4, half-maximal inhibitory concentration: 241 nM
Beside the measured number, compound 4's estimate is 6.0-fold (0.78 log units) below it; measured number above the stated range.
By their numbers in this assay, from the lowest: compound 1; then compound 3; then compounds 4 and 2 (each within the scatter of the next).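

In this assay, the ether tail of compound 1 proves to be a sensitive position: going from 2,2-difluoroethoxy to methoxy gives a 16-fold higher number from compound 1 to compound 4 (1.21 log units; beyond the scatter). This is the first pair shown that isolates this position on a single core, and the step is large for a change of only 3 heavy atoms, none of them a hydrogen-bond donor or acceptor. Nothing available explains why so small a change has so large an effect.

This one step removes the fluorine atoms and shortens the chain together, so the two changes cannot be told apart. A plain ethoxy tail would separate them by keeping the chain without fluorine, while a 2,2,2-trifluoroethoxy tail would show how the number moves with one more fluorine atom.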